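Adding 2,3-dihydroxypropyl to the amide of compound 3

The compounds below may be only part of what the source reports. "The series", "measured", "known", "first", "only" and "open" are said of these compounds alone.

Compound 1 `O=C(Nc1nnc(Cc2cccc(Cl)c2)s1)c1ccc(O[C@H]2CC[C@@H](C(=O)O)CC2)nc1`: 8000 nM
Compound 2 `O=C(Nc1nnc(NC2CCCC2)s1)c1ccc(O[C@H]2CC[C@@H](C(=O)O)CC2)cc1`: 26000 nM
Compound 3 `NC(=O)C[C@H]1CC[C@H](c2ccc(C(=O)Nc3nnc(Cc4ccccc4)s3)cc2)CC1`: < 2000 nM (a limit)

All three compounds were tested in a physicochemical assay for solubility, read by HPLC, in phosphate buffer, with a stated time of 20 h, at pH 7.4; a lower number here means a less soluble compound, a higher number a more soluble compound. Compound 1 and compound 2 each return a number there. Compound 3 gives < 2000 nM, which is a limit and not a number. Compound 3 therefore stands at the limit of < 2000 nM in this assay, at which 1 of the 3 values shown sits.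

Compound 4 `O=C(C[C@H]1CC[C@H](c2ccc(C(=O)Nc3nnc(Cc4ccccc4)s3)cc2)CC1)NCC(O)CO` keeps the core of compound 3 and differs from it in one place: 2,3-dihydroxypropyl in place of hydrogen on an amide-type nitrogen. In words, 2,3-dihydroxypropyl takes the place of hydrogen on an amide-type nitrogen, so that carbamoylmethyl becomes ((2,3-dihydroxypropyl)carbamoyl)methyl. The entering group brings no ring and no net charge.

Going by the values given here, no pair of measured compounds shows this change, so the size of the step in this assay cannot be read from a measured example. A modest rise is expected, not far beyond the scatter, and a result that again returns only a limit would fit that expectation. The expected change is an at least 1.5-fold higher number from compound 3 to compound 4 (0.17 log units; that floor lies within the scatter), an estimate that starts from a limit. For compound 4 the estimated value is 3000 nM, with an expected range of 1000 nM to 12000 nM.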

Compound 4, solubility: < 2000 nM
Compound 4: only a limit was reported (the forecaster's own chance of this, stated with the estimate: 40%); middle value at least 1.5-fold (0.17 log units) away from the limit.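

In this assay compound 4 gives < 2000 nM, which is a limit and not a number. Compound 3 stands at a limit there too, so no step can be read between compound 3 and compound 4: the limit of < 2000 nM in this assay, at which 2 of the 4 values shown sit.

The compounds shown leave open whether 2,3-dihydroxypropyl in place of hydrogen on an amide-type nitrogen changes the result in this assay at all.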